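This account rests on a few compounds, and the source may have more. Where it says the series, first, only, none or still open, it means among the compounds named here.

Measured in a functional assay on HUVEC cells (Homo sapiens) for inhibition, with stated times of 2 h and 72 h; a higher number here means a weaker inhibitor, a lower number a stronger inhibitor:
- Compound 1 `COc1cc2nccc(Oc3ccc4c(NC(=O)c5cc(C(F)(F)F)cc(C(F)(F)F)c5)nn(C)c4c3)c2cc1OC`: > 1000 nM (a limit)
- Compound 2 `COc1cc2nccc(Oc3ccc4c(NC(=O)Nc5ccc(C(F)(F)F)cc5Cl)nn(C)c4c3)c2cc1OC`: > 1000 nM (a limit)
- Compound 3 `COc1ccc(C(=O)Nc2nn(C)c3cc(Oc4ccnc5cc(OC)c(OC)cc45)ccc23)cc1`: > 1000 nM (a limit)

Compound 3 has no numerical value, only the limit of > 1000 nM. It shares this position with the other two compounds, so the whole set rests on (the limit of > 1000 nM in this assay, at which 3 of the 3 values shown sit). Nothing in these results places any of the three ahead of another.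

Compound 4 `COc1ccc(NC(=O)Nc2nn(C)c3cc(Oc4ccnc5cc(OC)c(OC)cc45)ccc23)cc1` is the next to be considered. The change from compound 3 is (4-methoxyphenyl)amino in place of 4-methoxyphenyl on a carbonyl carbon. In words, (4-methoxyphenyl)amino stands in place of 4-methoxyphenyl on a carbonyl carbon.

Among the compounds with values here, only one measured step bears on this change: a step that the two limits leave unreadable from compound 2 to compound 3. It also concerns the group on that carbonyl carbon, but it offers no size to carry over. Compound 2 does carry an amino group there, and its result is still the limit of > 1000 nM.

No clear gain is therefore expected in this assay, though a modest one cannot be excluded. The expected change is a step that the limit leaves unreadable from compound 3 to compound 4, and its starting point is only a limit. For compound 4 the estimate is 1500 nM, with an expected range from 250 nM to 5000 nM.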

Compound 4, half-maximal inhibitory concentration: > 1000 nM
Compound 4 was reported as a limit; the forecaster's own chance of this, stated with the estimate: 65%; the middle value does not contradict the limit.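

In this assay compound 4 gives > 1000 nM, which is a limit and not a number. Within the data shown here, no step from compound 2 or compound 3 to compound 4 can be read, and the whole set sits at one value: the limit of > 1000 nM in this assay, at which 4 of the 4 values shown sit. The compounds shown leave open whether the group on the carbonyl carbon affects inhibition at all.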